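Phenolic cinnamate esters: hydroxy to methoxy in a cytotoxicity series

The compounds below may be only part of what the source reports. "The series", "measured", "known", "first", "only" and "open" are said of these compounds alone.

Measured compounds:
compound 1 `O=C(/C=C/c1ccc(OCCCCO[N+](=O)[O-])c(O)c1)OCCCCO[N+](=O)[O-]`: > 50000 nM
compound 2 `O=C(/C=C/c1ccc(O)c(O)c1)OCc1c(-c2ccccc2)no[n+]1[O-]`: 14200 nM
compound 3 `COc1cc(/C=C/C(=O)OCc2c(-c3ccccc3)no[n+]2[O-])ccc1O`: 13400 nM

All three were run in a functional assay on H266 cells (Homo sapiens) for cytotoxicity, read by resazurin assay, with a stated time of 72 h; a lower number here means a stronger inhibitor, a higher number a weaker inhibitor. For compound 1 the value > 50000 nM is a limit of the assay, not a number (the limit of > 50000 nM in this assay, at which 1 of the 3 values shown sits). Compound 2 gives 14200 nM and compound 3 gives 13400 nM in this assay; these two sit within the scatter of each other, so no order between them is claimed.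

The pair compound 2 to compound 3 differs in one place (methyl in place of hydrogen on an oxygen on an aromatic ring). The step of a 1.1-fold lower number from compound 2 to compound 3 (0.03 log units; within the scatter) is within the scatter, so this change left the read-out unmoved on that core.

Compound 4 `COc1cc(/C=C/C(=O)OCCCCO[N+](=O)[O-])ccc1OCCCCO[N+](=O)[O-]` is not yet measured. It stands to compound 1 as compound 3 stands to compound 2: the same change (methyl in place of hydrogen on an oxygen on an aromatic ring), at a place described in the same words. The difference between the two cores, compound 1 against compound 2, is not broken down here.

Because the matching change gave a 1.1-fold lower number from compound 2 to compound 3 (0.03 log units; within the scatter), the step from compound 1 to compound 4 is expected to be small as well, a step that the limit leaves unreadable from compound 1 to compound 4, and since compound 1 sits only at a limit, compound 4 is most likely to be reported at a limit too. The estimate for compound 4 in this assay is 60000 nM, with a range from 30000 nM to 150000 nM. This rests on one measured pair only, so it is a weak expectation.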

Compound 4, half-maximal inhibitory concentration: > 50000 nM
Compound 4: only a limit was reported (the forecaster's own chance of this, stated with the estimate: 85%); the middle value lies beyond the limit too.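

In this assay compound 4 gives > 50000 nM, which is a limit of the assay and not a number. Compound 1 also sits at a limit, so no step from compound 1 to compound 4 can be read: the limit of > 50000 nM in this assay, at which 2 of the 4 values shown sit.

The compounds shown leave open whether hydroxy to methoxy moves the read-out at all on the core of compound 1.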